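The source may report more compounds than this note shows. Statements on the series, on what has been measured and on what is new or still open speak of the compounds shown alone.

Working notes on the series. Compound 1 `O=C(NO)c1ccc(NCc2nc(-c3cccnc3)nn2-c2ccccc2)cc1` was tested in an assay on Sf9 cells for inhibition of protein deacetylase HDAC6 (Homo sapiens), read by fluorescence, with a stated time of 40 min, tested at 100 nM (a higher number here means more inhibition at the concentration tested (going by the name of the read-out), a lower number less inhibition), and gives 57.7%. Compound 2 `O=C(NO)c1ccc(NCc2nc(-c3ccccc3)nn2-c2ccc(F)cc2)cc1` gives 67.6% in the same assay, and compound 3 `O=C(O)c1ccc(NCc2nc(-c3ccccc3)nn2-c2ccccc2)cc1` gives -0.4%. Among these three numbers compound 1 has the second highest; its nearest neighbour is compound 2, whose number lies within the usual scatter of compound 1, so no order is drawn between the two, while compound 3 lies far lower, well beyond the scatter. Within the data shown here, no two measured compounds differ in a single place, so no single-point step has been measured within the set.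

The next compound, compound 4 `O=C(NO)c1ccc(NCc2nc(-c3ccsc3)nn2-c2ccccc2)cc1`, differs from compound 1 in one place: thiophen-3-yl in place of pyridin-3-yl on an aromatic carbon. Among the measured compounds shown here, there is no measured step of this kind to lean on; from the values of compound 1 and compound 2 the expected step in this assay is small, a number 2.3 percentage points higher from compound 1 to compound 4 (within the scatter), and most likely within the scatter in either direction. For compound 4 the expected inhibition in this assay is 60%, with a range from 42% to 76%.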

Compound 4, a percentage reported as inhibition, at one concentration (the size of the read-out at that concentration, not a potency): 53.4%
Compound 4: the middle estimate sits 6.6 percentage points above what was measured; the measured number falls inside the stated range.
By their numbers in this assay, from the lowest: compound 3; then compounds 4, 1 and 2 (each within the scatter of the next, the first and the last beyond it).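

In this assay, thiophen-3-yl in place of pyridin-3-yl on this aromatic carbon gives a number 4.3 percentage points lower from compound 1 to compound 4 (within the scatter), the first single-place step measured in the series. At this position, therefore, a five-membered aromatic ring with sulfur and a six-membered aromatic ring with one nitrogen cannot be told apart, and no order is drawn between compound 1 and compound 4. No supporting measurement bears on why the two read alike.

Only aromatic rings occupy this carbon in the compounds shown, so it remains open whether an amine, a carboxylic acid or a longer alkyl chain there would also stay within the scatter of compound 1. From the compounds shown here alone, it is also open whether the same exchange would read alike with the fluorine of compound 2 in place.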